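The source may hold more compounds than are shown below. What is called first, only, known or untested is meant among the compounds shown, and "the series" means these compounds.

Measured compounds:
- compound 1 `C=CCN1C(=C(C(=O)OCC)C(=O)OCC)N([C@H]2OC(CO)[C@H]3OC(C)(C)O[C@H]32)c2cc(N)nc(O)c21`; in a functional assay on the whole organism (B cells) with Mus musculus as the target (on this read-out higher numbers stand for larger maximal responses and lower numbers for smaller maximal responses), compound 1 gives 0%
- compound 2 `COc1ccc(Cn2c(=O)n(C3OC(CO)[C@@H](O)[C@H]3O)c3nc(N)nc(O)c32)cc1`; in this assay compound 2 gives 44%

Of the two numbers recorded in this assay, compound 2 holds the higher, and its gap to compound 1 lies beyond the scatter. Among the measured compounds shown here, compound 1 and compound 2 share no single point of difference, so no step between them is counted; only their two values stand side by side.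

The next compound, compound 3 `N#Cc1cccc(Cn2c(=O)n(C3OC(CO)[C@@H](O)[C@H]3O)c3nc(N)nc(O)c32)c1`, is derived from compound 2 by one change: 3-cyanophenyl in place of 4-methoxyphenyl on a saturated chain carbon bound to an aromatic nitrogen. For the measured compounds named here, no measured pair isolates that kind of exchange, so no counted step supports any direction for it. With the remainder of compound 2 kept intact, the expected step in this assay is small, in either direction, and likely within the scatter.

Compound 3 is therefore expected to stay close to compound 2 in this assay, with an estimated step of a number 4 percentage points lower from compound 2 to compound 3 (within the scatter). The estimate for compound 3 in this assay is 40%, in a range from 15% to 65%.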

Compound 3, largest response reached (reported as maximal response), in percent of the reference or control that the assay uses: 16%
For compound 3 the middle estimate is 24 percentage points above the measured one, within the range that was stated.
By their numbers in this assay, from the lowest: compound 1; then compound 3; then compound 2.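

In this assay, among the compounds shown here, the exchange of 4-methoxyphenyl for 3-cyanophenyl on a saturated chain carbon bound to an aromatic nitrogen gives the first counted step, a number 28 percentage points lower from compound 2 to compound 3 (beyond the scatter). This position is therefore not indifferent to the aryl group it carries: the two groups match in heavy-atom count, ring type, hydrogen-bond donors and hydrogen-bond acceptors, yet compound 2 gives 44% and compound 3 gives 16%. No available measurement bears on the origin of this drop, so the step stands as an observation only.

For the compounds shown here, the single step replaces the substituent on the phenyl ring and moves its place on that ring at once, so the two contributions remain unseparated. Also open, from the compounds shown here alone, is how the maximal response would stand at this position with a plain phenyl, with a phenyl carrying an amine or a carboxylic acid, or with a longer chain in place of the benzyl carbon.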